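From 2-hydroxyphenyl to furan-2-yl on the shared core

A few compounds are considered here, and "the series" means these few. Any claim that something is new, unique, unknown or untested is made for them only; others in the source may bear on it.

Compound 1 `O=C(CSc1nnc(-c2ccncc2)o1)N/N=C/c1cccc(F)c1`: 19500 nM
Compound 2 `COc1cccc(/C=N/NC(=O)CSc2nnc(-c3ccncc3)o2)c1`: 9170 nM
Compound 3 `O=C(CSc1nnc(-c2ccncc2)o1)N/N=C/c1ccccc1O`: 3510 nM

In a functional assay on HepG2 cells (Homo sapiens) for cytotoxicity, read by MTT assay, with a stated time of 48 h (on this read-out higher numbers stand for weaker inhibition and lower numbers for stronger inhibition), compound 3 has the lowest of the three numbers, 3510 nM. Compound 4 `O=C(CSc1nnc(-c2ccncc2)o1)N/N=C/c1ccco1` has furan-2-yl in place of 2-hydroxyphenyl on a carbon with a double bond to nitrogen. Going by the values given here, no measured compound carries furan-2-yl. The closest evidence is a 5.6-fold lower number from compound 1 to compound 3 (0.74 log units; beyond the scatter) and a 2.6-fold lower number from compound 2 to compound 3 (0.42 log units; beyond the scatter), both modest and both ending at the 2-hydroxyphenyl compound. Losing that group is therefore expected to raise the number by a similarly modest amount, and a step of a 2.6-fold higher number from compound 3 to compound 4 (0.41 log units; beyond the scatter) is expected. For compound 4 the estimated value is 9000 nM, with an expected range of 3000 nM to 25000 nM.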

Compound 4, half-maximal inhibitory concentration: 12500 nM
For compound 4 the middle estimate is 1.4-fold (0.14 log units) below the measured one; measured number inside the range.
By their numbers in this assay, from the lowest: compound 3; then compounds 2, 4 and 1 (each within the scatter of the next, the first and the last beyond it).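

In this assay a five-membered ring at this carbon does not keep the low number of the 2-hydroxyphenyl group (a 3.6-fold higher number from compound 3 to compound 4 (0.55 log units; beyond the scatter)). The furan-2-yl group lies within the scatter of the 3-methoxyphenyl group (a 1.4-fold higher number from compound 2 to compound 4 (0.13 log units; within the scatter)) and of the 3-fluorophenyl group (a 1.6-fold lower number from compound 1 to compound 4 (0.19 log units; within the scatter)), so 2-hydroxyphenyl alone stands beyond the scatter of all three other groups. Nothing available explains these differences. Still open, as far as these compounds go, is whether an unsubstituted phenyl or an aminophenyl group would keep the low number of 2-hydroxyphenyl.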